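The source may hold more compounds than are shown below. What is called first, only, known or untested is meant among the compounds shown, and "the series" means these compounds.

All the compounds here carry a heptyl chain on a shared kind of core, and the question is how much of each dissolves. In a physicochemical assay for solubility, read by HPLC, at pH 7.4 (on this read-out higher numbers stand for higher solubility and lower numbers for lower solubility), compound 3 `CCCCCCCc1[nH]c2ccccc2c(=O)c1CO` gives 50000 nM. Among the measured compounds shown here, compound 2 `CCCCCCCc1cc(=O)c2cc(C(F)(F)F)ccc2n1C` gives 5000 nM, so compound 3 holds the higher of the only two true numbers available, and the gap between them lies beyond the usual scatter of repeated measurements. Compound 1 `CCCCCCCc1cc(=O)c2cc([N+](=O)[O-])ccc2[nH]1` reads < 5000 nM, which is a limit of the assay and not a number.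

Compound 4 `CCCCCCCc1[nH]c2ccc([N+](=O)[O-])cc2c(=O)c1CO` is compound 3 with a single change: nitro in place of hydrogen on an aromatic carbon. In words, nitro takes the place of hydrogen on an aromatic carbon of a six-membered aromatic ring of carbon only. For the measured compounds named here, no measured pair of compounds shows this change on its own, so any forecast rests on thin evidence. Going by the values given here, the one pointer is compound 1, which also carries a nitro group and whose reading of < 5000 nM is a limit. On that basis, a downward step beyond the scatter is expected, with an estimated size of a 4.2-fold lower number from compound 3 to compound 4 (0.62 log units; beyond the scatter). For compound 4 the estimated value is 12000 nM, with an expected range from 4000 nM to 35000 nM.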

Compound 4, solubility: 5000 nM
For compound 4 the middle estimate is 2.4-fold (0.38 log units) above the measured one; the measured number falls inside the stated range.
By their numbers in this assay, from the lowest: compounds 2 and 4 (each within the scatter of the next); then compound 3.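

Among the compounds shown here, until now, nitro on this aromatic carbon, meta to a fused ring and para to a fused ring, had no measured size, and the only other nitro compound offered nothing firm. In this assay, nitro in place of hydrogen on this aromatic carbon gives a 10-fold lower number from compound 3 to compound 4 (1.00 log units; beyond the scatter), so the change has a readable size on a core that also carries hydroxymethyl. Compound 1 holds only a limit and not a number: the limit of < 5000 nM in this assay, at which 1 of the 4 values shown sits. The remaining comparison gives a number no lower from compound 1 to compound 4 (the limit leaves the size open), so it cannot be read and adds no size.

The compounds shown leave open what an amine or a carboxylic acid on the same aromatic carbon would give. They also leave open whether nitro would bring a step of similar size with a longer chain in place of the heptyl chain, as this single pair is the only direct measure of the change.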